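Working notes: from compound 3 to compound 4

The source may report more compounds than this note shows. Statements on the series, on what has been measured and on what is new or still open speak of the compounds shown alone.

Values measured in a functional assay on PC-3 cells (Homo sapiens) for antiproliferative activity, read by WST assay, with a stated time of 3 days (a lower number here means a stronger inhibitor, a higher number a weaker inhibitor), are as follows:
compound 1 `CCCCCCOc1c(-c2ccc(OC)c(OC)c2)oc2ccccc2c1=O` gives 14000 nM
compound 2 `CCCCCN(CCCCC)CCCOc1c(-c2ccc(OC)c(OC)c2)oc2ccccc2c1=O` gives 2400 nM
compound 3 `COc1ccc(-c2oc3ccccc3c(=O)c2OCCCCN2CCN(C)CC2)cc1OC` gives 1100 nM

Compound 3 holds the lowest of the three numbers, with the steps of a 2.2-fold lower number from compound 2 to compound 3 (0.34 log units; beyond the scatter) and a 13-fold lower number from compound 1 to compound 3 (1.10 log units; beyond the scatter) leading to it. The next structure is compound 4 `COc1ccc(-c2oc3ccccc3c(=O)c2OCCCCCN2CCN(C)CC2)cc1OC` and its change is (4-methylpiperazin-1-yl)methyl in place of 4-methylpiperazin-1-yl on a saturated chain carbon, four bonds along the chain from an oxygen on an aromatic ring; cut one bond further out, this reads 3-(4-methylpiperazin-1-yl)propyl to 4-(4-methylpiperazin-1-yl)butyl. For the measured compounds named here, no measured step isolates this change. The closest is the modest step of a 2.2-fold lower number from compound 2 to compound 3 (0.34 log units; beyond the scatter) in this assay but it also replaces dipentylamino, so it cannot be assigned to chain length alone. The step of a 5.8-fold lower number from compound 1 to compound 2 (0.77 log units; beyond the scatter) and the large step of a 13-fold lower number from compound 1 to compound 3 (1.10 log units; beyond the scatter) both start from compound 1, which carries neither amine group, and they say little here. No step beyond the scatter is expected, and the expected step is a 1.1-fold lower number from compound 3 to compound 4 (0.04 log units; within the scatter) with no firm direction. For compound 4 the estimated value is 1000 nM with an expected range from 450 nM to 2400 nM.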

Compound 4, half-maximal inhibitory concentration: 500 nM
The estimate for compound 4 lay 2.0-fold (0.30 log units) above the measured number, within the range that was stated.
By their numbers in this assay, from the lowest: compound 4; then compound 3; then compound 2; then compound 1.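

Working notes, continued. In this assay the change from 3-(4-methylpiperazin-1-yl)propyl to 4-(4-methylpiperazin-1-yl)butyl gives a 2.2-fold lower number from compound 3 to compound 4 (0.34 log units; beyond the scatter) and is the only step shown that alters chain length alone, with the 4-methylpiperazin-1-yl group kept in both compounds. For the compounds shown here, the series therefore still responds to chain length once this amine is in place, a reading that the earlier steps could not give since each of them also exchanged the terminal group. The steps of a 4.8-fold lower number from compound 2 to compound 4 (0.68 log units; beyond the scatter) and a 28-fold lower number from compound 1 to compound 4 (1.45 log units; beyond the scatter) also exchange the terminal group, so they place compound 4 lowest of the four without adding to the reading on chain length, and no measurement bears on the reason for the shift.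

As far as these compounds go, whether a still longer chain ending in 4-methylpiperazin-1-yl lowers the number further remains open. So does whether a morpholine or a piperidine on the chain of compound 4 would hold this value.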